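Mirror-image step from compound 3 to compound 4

The source may report more compounds than this note shows. Statements on the series, on what has been measured and on what is new or still open speak of the compounds shown alone.

The series is read in a functional assay on PC-3 cells (Homo sapiens) for cytotoxicity, read by MTT assay, with a stated time of 48 h, tested at 25 uM; a higher number here means a stronger effect of the compound at the concentration tested, a lower number a weaker effect. Compound 1 `O=C(c1ccc(O)cc1O)[C@H]1[C@H](c2ccccc2)[C@H](C(=O)c2ccc(O)cc2O)[C@@H]1c1ccccc1` gives 57.9% in this assay. Compound 2 `O=C(c1ccc(O)cc1O)[C@H]1[C@H](C(=O)c2ccc(O)cc2O)[C@H](c2ccccc2)[C@@H]1c1ccccc1` gives 87.6% in this assay. Compound 3 `O=C(c1ccc(O)cc1O)[C@H]1Cc2ccccc2[C@@H](C(=O)c2ccc(O)cc2O)[C@H]1c1ccccc1` gives 86.3% in this assay, the second highest of the three numbers: the value of compound 2 sits within the scatter of it, while the value of compound 1 lies beyond the scatter on the lower side.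

Compound 4 `O=C(c1ccc(O)cc1O)[C@@H]1Cc2ccccc2[C@H](C(=O)c2ccc(O)cc2O)[C@@H]1c1ccccc1` has not yet been measured in this assay. Against compound 3 the change is as follows: the two compounds have the same atoms and bonds and differ only in configuration as drawn: 3 of 3 stereo elements differ (all stereocentres are inverted: mirror images); a stereocentre at a saturated ring carbon is drawn S in compound 3 and R in compound 4; a stereocentre at a saturated ring carbon is drawn S in compound 3 and R in compound 4; a stereocentre at a saturated ring carbon is drawn S in compound 3 and R in compound 4. Among the compounds with values here, the measured set holds no mirror-image pair, so no step between two measured compounds shows what a full inversion does here. At a single concentration in this assay, the step is expected to stay within the scatter, in no clear direction; the expected step is a number 6.3 percentage points lower from compound 3 to compound 4 (within the scatter). Compound 4 is accordingly estimated at 80%, with a range from 60% to 95%, resting on compound 3 at 86.3%.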

Compound 4, a percentage reported as activity, at one concentration (the size of the read-out at that concentration, not a potency): 73.4%
For compound 4 the middle estimate is 6.6 percentage points above the measured one; low and high end bracket the measured number.
By their numbers in this assay, from the lowest: compound 1; then compound 4; then compounds 3 and 2 (each within the scatter of the next).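

In this assay, the series now holds its first mirror-image pair, and the step reads a number 12.9 percentage points lower from compound 3 to compound 4 (beyond the scatter). Configuration alone therefore moves this read-out, which no earlier comparison could show, and nothing else can account for the step because the pair offers no other difference: the fact that compounds 3 and 4 differ only in the configuration as drawn The step is modest and comes from a single concentration, so it describes the size of the read-out at that concentration and not a difference in potency.

Going by these compounds, all three stereocentres invert together, so the share of each in the step remains open. Also open, on these data alone, is whether a gap between mirror images persists when an amine or a carboxylic acid takes the place of a hydroxyl group on the shared core.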